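The source may report more compounds than this note shows. Statements on the series, on what has been measured and on what is new or still open speak of the compounds shown alone.

Compound 1 `O=S(=O)(Nc1ccc2oc(-c3ccccc3)nc2c1)c1ccccc1F` gives > 100000 nM in an assay on cells for inhibition of HSP60/HSP10 (Homo sapiens), with a stated time of 60 min; on this read-out lower numbers stand for stronger inhibition and higher numbers for weaker inhibition; this is a limit of the assay, not a number.
Compound 2 `O=S(=O)(Nc1ccc2oc(-c3ccccc3)nc2c1)c1cccc(Cl)c1` gives > 100000 nM in this assay; this too is a limit.
Compound 3 `O=S(=O)(Nc1ccc2oc(-c3ccccc3)nc2c1)c1ccccc1Cl` gives > 100000 nM in this assay; again a limit.

The three compounds share one core and differ only in the ring carried on the sulfonyl sulfur. Compound 3 stands where the other two stand: at the limit of the assay, the point at which all three values sit (the limit of > 100000 nM in this assay, at which 3 of the 3 values shown sit). For that reason the steps between them, a step that the two limits leave unreadable from compound 1 to compound 2, a step that the two limits leave unreadable from compound 1 to compound 3 and a step that the two limits leave unreadable from compound 2 to compound 3, have no readable size; they show only that no change of ring among these three brought a compound inside the measurable range.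

Compound 4 `O=S(=O)(Nc1ccc2oc(-c3ccccc3)nc2c1)c1ccccc1O` is the next compound. It differs from compound 3 in one place: hydroxy in place of chloro on an aromatic carbon. Going by the values given here, no measured step bears directly on this exchange, and the three steps that are known carry no size at all. Because every value shown sits at the limit (the limit of > 100000 nM in this assay, at which 3 of the 3 values shown sit), there is no ground to expect the new group to bring compound 4 inside the range. The expected step here is a step that the limit leaves unreadable from compound 3 to compound 4, that is, no readable movement. Compound 4 is therefore estimated at 150000 nM, within a range from 30000 nM to 600000 nM, most probably reported again only as a limit.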

Compound 4, half-maximal inhibitory concentration: 85000 nM
For compound 4 the middle estimate is 1.8-fold (0.25 log units) above the measured one, and the stated range covers the measured number.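

Of the four compounds, only compound 4 gives a readable number in this assay, while the others sit together at one point: the limit of > 100000 nM in this assay, at which 3 of the 4 values shown sit.

At this place on the ring, ortho to a large group, the change from 2-chlorophenyl to 2-hydroxyphenyl gives an at least 1.1-fold lower number from compound 3 to compound 4 (0.07 log units; that floor lies within the scatter), and the two related exchanges give an at least 1.1-fold lower number from compound 2 to compound 4 (0.07 log units; that floor lies within the scatter) and an at least 1.1-fold lower number from compound 1 to compound 4 (0.07 log units; that floor lies within the scatter). Each of these is only a floor, with a limit at one end, so the true size of the step cannot be read, and the steps among the three earlier compounds cannot be read at all. Going by these compounds alone, what the hydroxy group adds is therefore a first real number for this series, one that still stands high on this read-out and so marks a starting point rather than strong inhibition.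

The compounds shown leave open how an amine or a carboxylic acid would read at this same place on the ring. They also leave open how far compound 4 truly lies from the three compounds at the limit, and whether a change elsewhere on the shared core could bring the number much lower.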